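Phenyl in Place of Hydroxy on a Fused Core

A few compounds are considered here, and "the series" means these few. Any claim that something is new, unique, unknown or untested is made for them only; others in the source may bear on it.

Three measured compounds share a common core and differ in one group on an aromatic carbon or in how the same atoms are joined. Compound 1 `CN1CCC[C@H]1[C@H]1COc2cc(O)ccc2O1` carries a hydroxy group, and in an assay on membranes from Cerebral cortex for displacement of a labelled ligand from Neuronal acetylcholine receptor; alpha4/beta2 (Rattus norvegicus), with a stated time of 5 min (a lower number here means a stronger inhibitor, a higher number a weaker inhibitor), compound 1 gives 71000 nM. Compound 2 `CN1CCC[C@H]1[C@H]1COc2c(O)cccc2O1` has the same atoms joined differently; the difference between the two cores is not broken down here. In this assay compound 2 gives 1700 nM, the lowest of the three numbers. Compound 3 `CN1CCC[C@H]1[C@H]1COc2cc(-c3ccccc3)ccc2O1` arises from compound 1 by phenyl in place of hydroxy on an aromatic carbon, and in this assay compound 3 gives 92000 nM, so a 1.3-fold higher number from compound 1 to compound 3 (0.11 log units; within the scatter). Compound 4 `CN1CCC[C@H]1[C@H]1COc2c(cccc2-c2ccccc2)O1` is unmeasured and arises from compound 2 by phenyl in place of hydroxy on an aromatic carbon. This is the same kind of change, but the place differs: in compound 3 the phenyl is meta to a fused ring and para to a fused ring, in compound 4 it is ortho to a fused ring and meta to a fused ring. Because the earlier step of a 1.3-fold higher number from compound 1 to compound 3 (0.11 log units; within the scatter) was small, compound 4 is expected to move only modestly, with an expected step of a 2.4-fold higher number from compound 2 to compound 4 (0.37 log units; beyond the scatter). Compound 4 is estimated at 4000 nM, between 1000 nM and 20000 nM.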

Compound 4, inhibition constant: 7300 nM
Estimate against measurement, compound 4: 1.8-fold (0.26 log units) below, and the stated range covers the measured number.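

In this assay phenyl in place of hydroxy gives a 4.3-fold higher number from compound 2 to compound 4 (0.63 log units; beyond the scatter) on the core of compound 2. The same change therefore does not carry over with the same size from one core to the other: the same change on two cores in this assay, a 1.3-fold higher number (0.11 log units; within the scatter) from compound 1 to compound 3 and a 4.3-fold higher number (0.63 log units; beyond the scatter) from compound 2 to compound 4, 3.3-fold (0.52 log units) apart, beyond the scatter of two such steps. These two pairs show that a step measured on one core cannot simply be copied to another, but they cannot separate the effect of the different core from that of the different place of the phenyl.

The compounds shown leave open how an amine, a carboxylic acid or a longer chain in place of the hydroxy would compare on either core. They also leave open whether the gap between the two steps would hold for any such group.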